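The source may report more compounds than this note shows. Statements on the series, on what has been measured and on what is new or still open speak of the compounds shown alone.

Measured so far:
Compound 1, `CCN(CC)CCCOc1cc2ncnc(Nc3nc4ccc(C(=O)Nc5c(C)cccc5C)cc4s3)c2cc1OC`: in a functional assay on A549 cells (Homo sapiens) for cytotoxicity, read by WST assay, with a stated time of 72 h (a lower number here means a stronger inhibitor, a higher number a weaker inhibitor), compound 1 gives > 100000 nM, which is a limit of the assay and not a number.
Compound 2, `COc1cc2c(Nc3nc4ccc(C(=O)Nc5c(C)cccc5C)cc4s3)ncnc2cc1OCCCN1CCCCC1`: compound 2 gives > 100000 nM, likewise a limit and not a number.

Among the measured compounds shown here, the only measured step, a step that the two limits leave unreadable from compound 1 to compound 2, cannot be read, since both of its ends sit at the limit of > 100000 nM in this assay, at which 2 of the 2 values shown sit. Compound 2 therefore stands only at that limit among the values shown, with no number attached to it.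

Compound 3, `COc1cc2c(Nc3nc4ccc(C(=O)Nc5c(C)cc(C)cc5C)cc4s3)ncnc2cc1OCCCN1CCCCC1`, is not yet measured. It differs from compound 2 by methyl in place of hydrogen on an aromatic carbon. No measured step bears on this change, and the single step that exists is unreadable, so neither a direction nor a size can be drawn from the shown values; the starting point is itself a limit. The expected step is a step that the limit leaves unreadable from compound 2 to compound 3, no change beyond the scatter. For compound 3 the estimate is 150000 nM, with a range from 40000 nM to 600000 nM, most likely reported again as a limit.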

Compound 3, half-maximal inhibitory concentration: 10300 nM
Estimate against measurement, compound 3: 15-fold (1.16 log units) above; the whole stated range lies above it.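

In this assay, among the compounds shown here, the aromatic carbon para to a large group and meta to two methyl groups is the first place where a change gives a readable response: going from 2,6-dimethylphenyl to 2,4,6-trimethylphenyl gives an at least 9.7-fold lower number from compound 2 to compound 3 (0.98 log units; beyond the scatter). With 10300 nM, compound 3 is the first compound shown with a number, so one added methyl at this carbon is enough to bring the series into the measurable range. The size of this step is only a lower bound, as the starting point is a limit and not a number: the limit of > 100000 nM in this assay, at which 2 of the 3 values shown sit.

From the compounds shown here alone, whether another group at this carbon, such as chloro, methoxy or ethyl, would do the same remains open. The step between the diethylamino and piperidin-1-yl chains cannot be read, so it is also unknown whether the added methyl would have the same effect with diethylamino at the chain end.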